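A few compounds are considered here, and "the series" means these few. Any claim that something is new, unique, unknown or untested is made for them only; others in the source may bear on it.

Two members of a shared core have been measured in a functional assay on RKE cells for antagonist activity at Vasoactive intestinal polypeptide receptor 1 (Rattus norvegicus), read by HTRF and cAMP accumulation, with stated times of 10 min and 30 min; on this read-out higher numbers stand for weaker inhibition and lower numbers for stronger inhibition. Compound 1 `CC(C)c1cc(C(C)(C)C)cc(-c2cccc(-c3ccccc3)c2)c1CO` gives 210 nM in this assay, and compound 2 `CSc1cccc(-c2cc(C(C)(C)C)cc(C(C)C)c2CO)c1` gives 170 nM. Within the data shown here, the only change between them, methylsulfanyl in place of phenyl on an aromatic carbon, gave a 1.2-fold lower number from compound 1 to compound 2 (0.09 log units; within the scatter), so compound 2 stands at the low end of the two numbers while remaining within the scatter of compound 1.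

Compound 3 `CC(C)c1cc(C(C)(C)C)cc(-c2cccc(Cl)c2)c1CO` continues at the same aromatic carbon: chloro in place of methylsulfanyl on an aromatic carbon. Among the measured compounds shown here, only one measured step bears on this position, the one from compound 1 to compound 2, and it stayed within the scatter, which suggests that this ring position tolerates exchange of its substituent without a large shift in this assay. Nothing measured here, however, covers chloro itself, so the expectation is correspondingly loose. Compound 3 is therefore expected to land close to compound 2, with an estimated step of a 1.2-fold higher number from compound 2 to compound 3 (0.07 log units; within the scatter) that falls within the scatter. The estimate for compound 3 in this assay is 200 nM, with a range from 80 nM to 500 nM.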

Compound 3, half-maximal inhibitory concentration: 100 nM
For compound 3 the middle estimate is 2.0-fold (0.30 log units) above the measured one, within the range that was stated.
By their numbers in this assay, from the lowest: compounds 3, 2 and 1 (each within the scatter of the next, the first and the last beyond it).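

In this assay, among these compounds, chloro in place of methylsulfanyl gave a 1.7-fold lower number from compound 2 to compound 3 (0.23 log units; within the scatter), while chloro in place of phenyl gave a 2.1-fold lower number from compound 1 to compound 3 (0.32 log units; beyond the scatter), the first step at this aromatic carbon to pass beyond the scatter, though only modestly. The position therefore no longer looks entirely flat, yet compound 2 remains within the scatter of both neighbours, so only the two ends of the series, compound 1 and compound 3, can be told apart, and the three groups do not form separate levels. Nothing available accounts for the separation between those two ends.

The compounds shown leave open how other groups on this aromatic carbon, such as fluoro, methoxy, an amine or a carboxylic acid, would read out, and so whether chloro is in any way special or simply one of many tolerated groups. They also leave open whether the modest gain of chloro over phenyl would persist if the rest of the shared core were changed, as all three compounds carry the same remaining groups.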